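Phenyl for Fluoro on the Pyridine of Compound 2

This account rests on a few compounds, and the source may have more. Where it says the series, first, only, none or still open, it means among the compounds named here.

Measured compounds in an in vitro assay on SH-SY5Y cells for displacement of a labelled ligand from Neuronal acetylcholine receptor; alpha3/beta4 (Homo sapiens); a lower number here means a stronger inhibitor, a higher number a weaker inhibitor:
compound 1, `CN1C[C@H]2C=C(c3cccnc3)C[C@H](C2)C1`, gives 534 nM;
compound 2, `Fc1ccc(C2=CC3CNCC(C2)C3)cn1`, gives 28 nM;
compound 3, `CN1CC2C=C(c3ccc(F)nc3)CC(C2)C1`, gives 1310 nM.

Compound 2 holds the lowest number of the three in this assay; compound 1 sits a good deal higher, and compound 3 highest of all. Among the measured compounds shown here, the one change measured directly is a 47-fold higher number from compound 2 to compound 3 (1.67 log units; beyond the scatter), a large step that concerns the amine nitrogen in the ring and not the aromatic ring at all.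

Compound 4, `C1=C(c2ccc(-c3ccccc3)nc2)CC2CNCC1C2`, differs from compound 2 by phenyl in place of fluoro on an aromatic carbon. The amine nitrogen in the ring keeps its hydrogen, as in compound 2. For the measured compounds named here, no measured step touches this aromatic carbon, so the size and direction of the change in this assay cannot be read from the data; only the low starting point of compound 2 is known. A step of moderate size is therefore expected, in either direction, and most likely within or just beyond the scatter: the estimate is a 2.1-fold higher number from compound 2 to compound 4 (0.33 log units; beyond the scatter). Compound 4 is thus expected to give about 60 nM, in a range from 15 nM to 250 nM.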

Compound 4, inhibition constant: 507 nM
The estimate for compound 4 lay 8.5-fold (0.93 log units) below the measured number; measured number outside the range, above it.
By their numbers in this assay, from the lowest: compound 2; then compounds 4 and 1 (each within the scatter of the next); then compound 3.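

In this assay, phenyl in place of fluoro on the aromatic carbon next to the ring nitrogen gives an 18-fold higher number from compound 2 to compound 4 (1.26 log units; beyond the scatter), with the amine nitrogen in the ring still carrying its hydrogen. The earlier compounds shown here showed a large step only at that nitrogen; this result shows that a single change on the aromatic ring can also give a large step, in the same direction, and that fluoro and phenyl are far from interchangeable at this position. Nothing available explains this rise.

With only fluoro and phenyl shown on this carbon, it remains open whether chloro, methoxy or an amine there would stay near compound 2 or near compound 4. Also open, going by these compounds, is how phenyl at this position would fare with a methyl on the amine nitrogen in the ring.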